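Adding a second fluorine to a low-toxicity chalcone amide

The compounds below may be only part of what the source reports. "The series", "measured", "known", "first", "only" and "open" are said of these compounds alone.

Measured so far:
Compound 1 `CC(C)Cc1ccc(C(=O)/C=C/c2ccc(C(=O)O)cc2)cc1` gives in an ADME assay on Vero cells (Chlorocebus sabaeus) for cytotoxicity, read by MTT assay, with a stated time of 72 h (on this read-out higher numbers stand for lower toxicity in this test and lower numbers for higher toxicity in this test), only a limit, < 10 ug/mL.
Compound 3 `CCCOc1ccc(C(=O)/C=C/c2ccc(C(=O)O)cc2)cc1` gives in this assay only a limit, < 10 ug/mL.
Compound 2 `COC(=O)c1cc(-c2cccc(NC(=O)c3ccc(/C=C/C(=O)c4ccc(F)cc4)cc3)c2)on1` gives in this assay only a limit, > 20 ug/mL.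

Going by the values given here, the one pair differing in a single place is propoxy in place of isobutyl on an aromatic carbon, and its step that the two limits leave unreadable from compound 1 to compound 3 cannot be read, because the limit of < 10 ug/mL in this assay, at which 2 of the 3 values shown sit, is where both of its values sit. Compound 2 stands apart at the other end, because the limit of > 20 ug/mL in this assay, at which 1 of the 3 values shown sits, is a limit and not a number.

Compound 4 `COC(=O)c1cc(-c2cccc(NC(=O)c3ccc(/C=C/C(=O)c4ccc(F)cc4F)cc3)c2)on1` differs from compound 2 by fluoro in place of hydrogen on an aromatic carbon. Among the compounds with values here, no measured step involves a fluoro group, so none bears on this change, and the only step at hand is unreadable in size. With nothing to push the expectation away from where compound 2 stands, the expected step that the limit leaves unreadable from compound 2 to compound 4 is none beyond the scatter. Compound 4 is therefore estimated at 30 ug/mL, with a range from 15 ug/mL to 60 ug/mL.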

Compound 4, half-maximal cytotoxic concentration: > 40 ug/mL
Compound 4 ended at the assay's limit; the forecaster's own chance of this, stated with the estimate: 70%; at least 1.3-fold (0.12 log units) between middle value and limit.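

The step from compound 2 to compound 4 cannot be read, since both compounds give only a limit in this assay and not a number. The compounds shown leave open how far each true value lies past its limit, and so whether the added fluoro group changes the result at all.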